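Moving a Trifluoromethyl Group and Cell Toxicity

The compounds below may be only part of what the source reports. "The series", "measured", "known", "first", "only" and "open" are said of these compounds alone.

The compounds here were tested in an ADME assay on HEK293 cells (Homo sapiens) for cytotoxicity, read by MTT assay, with a stated time of 48 h; on this read-out lower numbers stand for stronger inhibition and higher numbers for weaker inhibition. Compound 1 has the structure `CN(c1ccc(NC(=O)c2cc(C(F)(F)F)cc(C(F)(F)F)c2)cc1OCc1cccc(C(F)(F)F)c1)S(C)(=O)=O`. For compound 1, this assay gives only a limit, > 500000 nM. Compound 2 has the structure `CN(c1ccc(NC(=O)c2cc(C(F)(F)F)cc(C(F)(F)F)c2)cc1OCc1ccccc1C(F)(F)F)S(C)(=O)=O`. For compound 2 as well, this assay gives only a limit, > 500000 nM. The two differ in one place: 2-(trifluoromethyl)phenyl in place of 3-(trifluoromethyl)phenyl on a saturated chain carbon bound to an oxygen on an aromatic ring. The step that the two limits leave unreadable from compound 1 to compound 2 cannot be read, because both values sit at the limit of > 500000 nM in this assay, at which 2 of the 3 values shown sit.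

Compound 3, with the structure `CN(c1ccc(NC(=O)c2ccc(C(F)(F)F)cc2C(F)(F)F)cc1OCc1cccc(C(F)(F)F)c1)S(=O)(=O)Cc1ccccc1`, is the only one of the measured three for which a number is seen: in this assay compound 3 gives 176000 nM. The difference between the core of compound 3 and the core of compound 1 is not broken down here.

Compound 4, with the structure `CN(c1ccc(NC(=O)c2ccc(C(F)(F)F)cc2C(F)(F)F)cc1OCc1ccccc1C(F)(F)F)S(=O)(=O)Cc1ccccc1`, has not yet been measured. It differs from compound 3 in one place: 2-(trifluoromethyl)phenyl in place of 3-(trifluoromethyl)phenyl on a saturated chain carbon bound to an oxygen on an aromatic ring. The place is the same as in the change from compound 1 to compound 2, so this is the same change made on a different core.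

Because the earlier step that the two limits leave unreadable from compound 1 to compound 2 is unreadable from two limits, nothing in the measured pairs shows this change moving the read-out, so a small step is expected: a 1.1-fold higher number from compound 3 to compound 4 (0.06 log units; within the scatter). Compound 4 is therefore estimated to give 200000 nM in this assay, with a plausible span from 80000 nM to 500000 nM.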

Compound 4, half-maximal inhibitory concentration: > 500000 nM
Compound 4: no number, only a limit; the forecaster's own chance of this, stated with the estimate: 30%; at least 2.5-fold (0.39 log units) between middle value and limit.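

On the core of compound 3, putting 2-(trifluoromethyl)phenyl in place of 3-(trifluoromethyl)phenyl on the saturated chain carbon gives, in this assay, an at least 2.8-fold higher number from compound 3 to compound 4 (0.45 log units; beyond the scatter), so on this core the change moves the read-out towards weaker inhibition. Compound 4 gives only a limit, > 500000 nM, so this step has a smallest size but no known full size. The same change on the core of compound 1 cannot be read, so this single readable pair does not show whether the effect carries from one core to another, and most of the series gives no number to compare: the limit of > 500000 nM in this assay, at which 3 of the 4 values shown sit.

The compounds shown leave open how large the step from compound 3 to compound 4 really is, and whether the change would give a step of similar size on the core of compound 1 if both partners gave numbers. They also do not tell how this assay would respond if a chlorine atom or a nitrile replaced the trifluoromethyl group on this benzyl ring, or if an amine or a carboxylic acid were carried there instead.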